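Working notes: pyrimidin-5-yl to phenoxy exchange

The compounds below may be only part of what the source reports. "The series", "measured", "known", "first", "only" and "open" are said of these compounds alone.

Compound 2 `COc1ccc(N2C[C@@H](C)N[C@@H](C)C2)cc1NS(=O)(=O)c1ccc(-c2cncnc2)cc1` stands level with compound 1 `COc1ccc(N2C[C@@H](C)N[C@@H](C)C2)cc1NS(=O)(=O)c1ccc(-c2ccncc2)cc1` in a functional assay for agonist activity at growth hormone secretagogue receptor type 1 (Homo sapiens), read by FLIPR; a higher number here means that more compound is needed for the effect, a lower number that less compound is needed: compound 2 gives 316 nM and compound 1 gives 316 nM. Going by the values given here, the single measured step, no change at the digits printed from compound 1 to compound 2 (within the scatter), shows that putting pyrimidin-5-yl in place of pyridin-4-yl on an aromatic carbon left the read-out unchanged within the scatter. Compound 3 `COc1ccc(N2C[C@@H](C)N[C@@H](C)C2)cc1NS(=O)(=O)c1ccc(Oc2ccccc2)cc1` is not yet measured; it differs from compound 2 by phenoxy in place of pyrimidin-5-yl on an aromatic carbon, the phenoxy group entering on an aromatic carbon para to a large group. Among the compounds with values here, the one step in hand bears on this only indirectly: it swapped two six-membered aromatic rings with hetero atoms that are directly attached, whereas here a ring of carbon only enters as phenoxy, and no measured pair covers that kind of change. Within the data shown here, the one recorded exchange was flat; no step beyond the scatter is expected in this assay in either direction, though the uncertainty is wider than for the measured step. Compound 3 is therefore estimated at 400 nM, with a range of 100 nM to 1600 nM, corresponding to an expected step of a 1.3-fold higher number from compound 2 to compound 3 (0.10 log units; within the scatter).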

Compound 3, half-maximal effective concentration: 63.1 nM
The estimate for compound 3 lay 6.3-fold (0.80 log units) above the measured number, outside the stated range (below it).
By their numbers in this assay, from the lowest: compound 3; then compounds 1 and 2 (each within the scatter of the next).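

At this position, on an aromatic carbon para to a large group, the read-out in this assay proves sensitive to the group carried: phenoxy in place of pyrimidin-5-yl gives a 5.0-fold lower number from compound 2 to compound 3 (0.70 log units; beyond the scatter) and phenoxy in place of pyridin-4-yl gives a 5.0-fold lower number from compound 1 to compound 3 (0.70 log units; beyond the scatter) on the same core. The flat exchange between the two directly attached rings with hetero atoms therefore does not describe the position as a whole, and compound 3 now stands lowest of the three, with both of its steps beyond the scatter. No measurement at hand accounts for this gain, so it stands as an observation only.

Phenoxy differs from the two departing groups both in its oxygen link and in its ring of carbon only, and the compounds shown leave open which of these two differences goes with the lower number. A directly attached phenyl and a pyridin-4-yloxy group at this position would separate the two, while benzyloxy would test whether a longer link is accepted.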